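Swapping the Aryl Group on an Acetylated Oxadiazoline Core

The source may report more compounds than this note shows. Statements on the series, on what has been measured and on what is new or still open speak of the compounds shown alone.

Measured compounds:
- compound 1, `CC(=O)N1N=C(c2ccc(-n3c(C)ccc3C)cc2)OC1c1cccc([N+](=O)[O-])c1`, 197000 nM
- compound 2, `Cc1ccc(C)n1-c1ccc(C(=O)N/N=C/c2ccc(Br)cc2)cc1`, "not determined" (no result reported)

Compound 1 carries a 3-nitrophenyl group on a saturated ring carbon of its core. Among the measured compounds shown here, in an ADME assay on A549 cells (Homo sapiens) for cytotoxicity, read by MTT assay, with a stated time of 72 h (on this read-out lower numbers stand for stronger inhibition and higher numbers for weaker inhibition), compound 1 gives 197000 nM, which is the only number in hand; compound 2, a hydrazone relative, was run but returned "not determined" (no result reported), so compound 1 stands alone and cannot be ranked against anything.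

Compound 3, `CC(=O)N1N=C(c2ccc(-n3c(C)ccc3C)cc2)OC1c1ccc(N(C)C)cc1`, is not yet measured. It differs from compound 1 in one place: 4-(dimethylamino)phenyl in place of 3-nitrophenyl on a saturated ring carbon. For the measured compounds named here, no measured pair in this set shows what such a swap does in this assay, so there is no precedent to lean on. With a single weak value as the only anchor, the expectation is that the step from compound 1 to compound 3 stays within the usual scatter, estimated as a 1.2-fold lower number from compound 1 to compound 3 (0.09 log units; within the scatter), with no clear direction. On that basis compound 3 is expected to give about 160000 nM in this assay, with a likely range from 50000 nM to 450000 nM.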

Compound 3, half-maximal inhibitory concentration: 186000 nM
Compound 3: the middle estimate sits 1.2-fold (0.07 log units) below what was measured; low and high end bracket the measured number.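

In this assay, among the compounds shown here, putting 4-(dimethylamino)phenyl in place of 3-nitrophenyl on a saturated ring carbon gives a 1.1-fold lower number from compound 1 to compound 3 (0.02 log units; within the scatter), the first measured step at this position. The two groups share a six-membered aromatic ring of carbon only but carry different substituents, one a nitro group and the other a dimethylamino group, and this exchange leaves the value within the scatter, so this one pair shows no sign that the choice between them matters in this assay. Nothing in hand accounts for this outcome.

What the compounds shown leave open is whether the substituent or its place on the aromatic ring counts here, since both differ in this single step, and a 4-nitrophenyl or a 3-(dimethylamino)phenyl group would separate the two. As far as these compounds go, it is also open whether the same holds for quite different groups at this ring carbon, such as a carboxylic acid on the phenyl ring or a saturated chain in place of the aromatic ring, or whether a longer acyl chain in place of the acetyl group would shift the value.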